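The source may report more compounds than this note shows. Statements on the series, on what has been measured and on what is new or still open speak of the compounds shown alone.

Measured compounds:
Compound 1 `COC(=O)N1CCN([C@H]2CC[C@H](Nc3ncnn4ccc([C@H](C)CC(=O)N(C)C)c34)CC2)CC1`: 18 10^-6 cm/s
Compound 2 `CC(=O)N1CCN([C@H]2CC[C@H](Nc3ncnn4ccc([C@H]5CC[C@H](C(N)=O)CC5)c34)CC2)CC1`: < 0.7 10^-6 cm/s, a limit

Among the compounds with values here, in an ADME assay on Caco-2 cells (Homo sapiens) for permeability, in the apical to basolateral direction (a lower number here means that the compound crosses the layer more slowly, a higher number that the compound crosses the layer faster), compound 1 gives 18 10^-6 cm/s, the only actual number available. Compound 2 gives only a limit, < 0.7 10^-6 cm/s.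

Compound 3 `COC(=O)N1CCN([C@H]2CC[C@H](Nc3ncnn4ccc(C(C)C)c34)CC2)CC1` differs from compound 1 by one change, hydrogen in place of dimethylcarbamoyl on a saturated chain carbon, two bonds along the chain from an aromatic carbon. Within the data shown here, no measured pair shows this change, so any forecast for this assay is tentative. A small rise is expected, possibly no larger than the usual scatter, with an estimated 1.4-fold higher number from compound 1 to compound 3 (0.14 log units; within the scatter). Compound 3 is estimated at 25 10^-6 cm/s, with an expected range of 10 10^-6 cm/s to 55 10^-6 cm/s.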

Compound 3, apparent permeability: 37 10^-6 cm/s
For compound 3 the middle estimate is 1.5-fold (0.17 log units) below the measured one; measured number inside the range.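

In this assay, hydrogen in place of dimethylcarbamoyl on a saturated chain carbon, two bonds along the chain from an aromatic carbon, gives a 2.1-fold higher number from compound 1 to compound 3 (0.31 log units; beyond the scatter), a modest step but beyond the scatter. Within the data shown here, it is the first measured step at this position, and it shows that the number goes up when 1-((dimethylcarbamoyl)methyl)ethyl gives way to isopropyl. Nothing shown accounts for this step. From the compounds shown here alone, whether an amine, a carboxylic acid or a longer chain at this place would move the number in the same direction remains open.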